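This account rests on a few compounds, and the source may have more. Where it says the series, first, only, none or still open, it means among the compounds named here.

In an ADME assay on HepG2 cells (Homo sapiens) for cytotoxicity, read by MTT assay, with a stated time of 72 h (a lower number here means that less compound is tolerated, a higher number that more compound is tolerated), compound 1 `CC1(c2ccc(-c3ccco3)cc2)CC(S(=O)(=O)c2ccc(F)cc2)=C(c2ccc(/C(N)=N\O)cc2)O1` gives 7010 nM as the lowest of three numbers, beyond the scatter from both others. Compound 2 `CC1(Cc2ccccc2)CC(S(=O)(=O)c2ccc(F)cc2F)=C(c2ccc(/C(N)=N\O)cc2)O1` gives 90600 nM and compound 3 `CC1(Cc2ccccc2)CC(S(=O)(=O)c2ccccc2C(F)(F)F)=C(c2ccc(/C(N)=N\O)cc2)O1` gives 57500 nM for comparison. Compound 4 `CC1(c2ccc(Br)cc2)CC(S(=O)(=O)c2ccc(F)cc2)=C(c2ccc(/C(N)=N\O)cc2)O1` keeps the core of compound 1 but carries bromo in place of furan-2-yl on an aromatic carbon is the whole change. Within the data shown here, the only measured single change is a 1.6-fold lower number from compound 2 to compound 3 (0.20 log units; within the scatter) and it concerns a group on a sulfonyl sulfur, not this place, so it offers only indirect guidance. Compounds 2 and 3 also differ from compound 1 in more than one place. In this assay a modest rise is therefore expected, an estimated 2.0-fold higher number from compound 1 to compound 4 (0.30 log units; within the scatter) with wide uncertainty. For compound 4 the expected value is 14000 nM within an estimated range of 5000 nM to 45000 nM overall.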

Compound 4, half-maximal cytotoxic concentration: 19200 nM
Compound 4: the middle estimate sits 1.4-fold (0.14 log units) below what was measured; the range from low to high includes it.
By their numbers in this assay, from the lowest: compound 1; then compound 4; then compounds 3 and 2 (each within the scatter of the next).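

Bromo in place of furan-2-yl on this aromatic carbon gives a 2.7-fold higher number from compound 1 to compound 4 (0.44 log units; beyond the scatter) in this assay. This is the first single change shown at this place, and unlike the earlier change on the sulfonyl sulfur, its step lies beyond the scatter. Nothing measured here accounts for the shift.

As far as these compounds go, whether an amine or a methoxy group on this carbon would give a number closer to that of bromo or of furan-2-yl stays open. So does whether the step would hold with a different group on the sulfonyl sulfur.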